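Chain extension toward compound 4 in the Amplex Red assay

This account rests on a few compounds, and the source may have more. Where it says the series, first, only, none or still open, it means among the compounds named here.

Compound 1 `C#CCN(C)CCCCOc1ccc2c(c1)CCC2=O` gives 7.93% in an ADME assay on BTI cells for inhibition of Amine oxidase [flavin-containing] A (Homo sapiens), read by fluorescence and Amplex Red, with a stated time of 15 min, tested at 100 uM; a lower number here means less inhibition, a higher number more inhibition at the concentration tested (going by the name of the read-out).
Compound 2 `C#CCN(C)CCCCCOc1ccc2c(c1)CCCC2=O` gives 26.1% in this assay.
Compound 3 `C#CCN(C)CCCOc1ccc2c(c1)OCCC2=O` gives 32.1% in this assay.

Among these three numbers, compound 3 stands highest. Its nearest neighbour is compound 2, whose number lies within the usual scatter of the measurement, so no order can be claimed between compound 2 and compound 3. Compound 1 is furthest from compound 3, with a number that lies beyond the scatter, and compound 1 differs from compound 3 in more than one place, so the two values are simply recorded side by side.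

Compound 4 `C#CCN(C)CCCCCOc1ccc2c(c1)OCCC2=O` has not yet been measured. It differs from compound 3 by 2-(methyl(propargyl)amino)ethyl in place of methyl(propargyl)amino on a saturated chain carbon, three bonds along the chain from an oxygen on an aromatic ring. No comparable single-site change has been measured among the three compounds, so the direction of the step is open. Because compound 2 gives 26.1% and compound 3 gives 32.1%, the step of a number 2.1 percentage points lower from compound 3 to compound 4 (within the scatter) is expected to stay within the scatter. Compound 4 is estimated at 30%, with a range from 10% to 55%.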

Compound 4, a percentage reported as inhibition, at one concentration (the size of the read-out at that concentration, not a potency): 6.04%
Compound 4: the middle estimate sits 24 percentage points above what was measured; measured number outside the range, below it.
By their numbers in this assay, from the lowest: compounds 4 and 1 (each within the scatter of the next); then compounds 2 and 3 (each within the scatter of the next).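

Going by these compounds alone, this is the first single-site step, and it shows that the chain in this position matters in this assay: 2-(methyl(propargyl)amino)ethyl in place of methyl(propargyl)amino gives a number 26.1 percentage points lower from compound 3 to compound 4 (beyond the scatter). The change leaves the shared core untouched and keeps the triple bond, the hydrogen-bond acceptor count and the net charge, so the two groups differ here in chain length alone. Nothing measured alongside these values accounts for the step.

With one step, the compounds shown leave open whether inhibition changes gradually or abruptly with chain length, and whether a longer chain would stay as low as compound 4. They also leave open whether a piperidine at the chain end would behave like methyl(propargyl)amino, and whether the same extension would matter on the other cores.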